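The source may report more compounds than this note shows. Statements on the series, on what has been measured and on what is new or still open speak of the compounds shown alone.

In a functional assay on HepG2 cells (Homo sapiens) for antiproliferative activity, read by CCK-8 assay, with a stated time of 48 h (a lower number here means a stronger inhibitor, a higher number a weaker inhibitor), compound 1 (`COc1ccc(/C=C\c2cc(OC)c(OC)c(OC)c2)cc1OCc1ccc(CN2CCCCC2C(=O)O)cc1`) gives 3100 nM and compound 2 (`COc1ccc(/C=C\c2cc(OC)c(OC)c(OC)c2)cc1OCc1ccc(CO)cc1`) gives 2400 nM so the two stand within the scatter of each other. Compound 3 (`COc1ccc(/C=C\c2cc(OC)c(OC)c(OC)c2)cc1OCc1ccc(CN2CC(C(=O)O)C2)cc1`) differs from compound 2 by 3-carboxyazetidin-1-yl in place of hydroxy on a saturated chain carbon bound to an aromatic carbon. Within the data shown here, the one measured step that bears on this is a 1.3-fold lower number from compound 1 to compound 2 (0.11 log units; within the scatter) where hydroxy replaced 2-carboxypiperidin-1-yl at that place, so no step beyond the scatter is expected in this assay here. The expected size is an estimated 1.2-fold higher number from compound 2 to compound 3 (0.07 log units; within the scatter) and no more. Compound 3 is estimated at 2800 nM with an expected range from 1200 nM to 6500 nM in this read-out.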

Compound 3, half-maximal inhibitory concentration: > 10000 nM
Compound 3 ended at the assay's limit (the forecaster's own chance of this, stated with the estimate: 5%); middle value at least 3.5-fold (0.55 log units) away from the limit.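

Compound 1 and compound 2 had suggested that, in this assay, the group on a saturated chain carbon bound to an aromatic carbon could change with little effect, yet 3-carboxyazetidin-1-yl in place of hydroxy gives an at least 4.1-fold higher number from compound 2 to compound 3 (0.61 log units; beyond the scatter). A carboxylic acid on a ring at this place does not settle the outcome by itself: 3-carboxyazetidin-1-yl in place of 2-carboxypiperidin-1-yl gives an at least 3.2-fold higher number from compound 1 to compound 3 (0.50 log units; beyond the scatter). The result for compound 3 is a limit of this assay, not a number: the limit of > 10000 nM in this assay, at which 1 of the 3 values shown sits.

As far as these compounds go, how far compound 3 lies past that limit stays open. From the compounds shown here alone, it is also open whether a plain amine in place of the carboxylic acid, or a longer chain carrying the acid, would follow compound 3 or compound 1.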